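Combining both methyl additions in compound 4

A few compounds are considered here, and "the series" means these few. Any claim that something is new, unique, unknown or untested is made for them only; others in the source may bear on it.

Among the compounds with values here, compound 3 `CCCCCc1nc(N)n(CC(=O)Nc2ccc(C)cc2)c1-c1ccccc1Br` gives 4300 nM in a functional assay on A-375 cells (Homo sapiens) for antiproliferative activity, read by MTT assay, with a stated time of 48 h (on this read-out lower numbers stand for stronger inhibition and higher numbers for weaker inhibition), the lowest of the three numbers so far; compound 2 `CCCCCCc1nc(N)n(CC(=O)Nc2ccccc2)c1-c1ccccc1Br`, at 5700 nM, lies within the scatter of it, while compound 1 `CCCCCc1nc(N)n(CC(=O)Nc2ccccc2)c1-c1ccccc1Br`, at 26400 nM, is the furthest away. Compound 4 `CCCCCCc1nc(N)n(CC(=O)Nc2ccc(C)cc2)c1-c1ccccc1Br` differs from compound 3 by methyl in place of hydrogen on a saturated chain carbon, five bonds along the chain from an aromatic carbon. The same change has been measured once, giving a 4.6-fold lower number from compound 1 to compound 2 (0.67 log units; beyond the scatter); the other step, a 6.1-fold lower number from compound 1 to compound 3 (0.79 log units; beyond the scatter), concerns the methyl on the aromatic carbon that compound 3 already carries. Compound 4 is therefore expected to show a 3.1-fold lower number from compound 3 to compound 4 (0.49 log units; beyond the scatter), a step in the same direction but allowed to come out somewhat smaller, and its estimated value is 1400 nM with a range from 600 nM to 3500 nM.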

Compound 4, half-maximal inhibitory concentration: 5100 nM
The estimate for compound 4 lay 3.6-fold (0.56 log units) below the measured number; the whole stated range lies below it.
By their numbers in this assay, from the lowest: compounds 3, 4 and 2 (each within the scatter of the next); then compound 1.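

On the core that already carries the methyl on the aromatic carbon, methyl in place of hydrogen on the saturated chain carbon gives a 1.2-fold higher number from compound 3 to compound 4 (0.07 log units; within the scatter), so the step seen on the core of compound 1 does not recur: the same change on two cores in this assay, a 4.6-fold lower number (0.67 log units; beyond the scatter) from compound 1 to compound 2 and a 1.2-fold higher number (0.07 log units; within the scatter) from compound 3 to compound 4, 5.5-fold (0.74 log units) apart, beyond the scatter of two such steps The methyl on the aromatic carbon likewise gives a 1.1-fold lower number from compound 2 to compound 4 (0.05 log units; within the scatter) on the core of compound 2: the same change on two cores in this assay, a 6.1-fold lower number (0.79 log units; beyond the scatter) from compound 1 to compound 3 and a 1.1-fold lower number (0.05 log units; within the scatter) from compound 2 to compound 4, 5.5-fold (0.74 log units) apart, beyond the scatter of two such steps The two additions therefore do not add up, and either one alone matches both together. On these data alone, whether this holds for a longer chain, such as heptyl, or for a carboxylic acid in place of the methyl on the aromatic carbon remains open.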